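Enlarging the Anilide Ring: Expecting a Fused-Ring Gain

The source may report more compounds than this note shows. Statements on the series, on what has been measured and on what is new or still open speak of the compounds shown alone.

The three measured compounds share one core and differ only in the aromatic ring attached to the amide-type nitrogen. Compound 1 `C[C@H](NC(=O)C(=O)Nc1ccccc1)C(=O)N[C@@H](CC(=O)O)C(=O)COc1c(F)c(F)cc(F)c1F` carries a plain phenyl there, and in a functional assay on Jurkat cells (Homo sapiens) for inhibition (on this read-out higher numbers stand for weaker inhibition and lower numbers for stronger inhibition), compound 1 gives 670 nM, the highest number of the three. Compound 2 `C[C@H](NC(=O)C(=O)Nc1ccccc1C(F)(F)F)C(=O)N[C@@H](CC(=O)O)C(=O)COc1c(F)c(F)cc(F)c1F` gives 61 nM, and compound 3 `C[C@H](NC(=O)C(=O)Nc1ccccc1-c1ccc[nH]1)C(=O)N[C@@H](CC(=O)O)C(=O)COc1c(F)c(F)cc(F)c1F` gives 56 nM. Each of these two differs from compound 1 by one group on that phenyl. The steps are an 11-fold lower number from compound 1 to compound 2 (1.04 log units; beyond the scatter) and a 12-fold lower number from compound 1 to compound 3 (1.08 log units; beyond the scatter), whereas a 1.1-fold lower number from compound 2 to compound 3 (0.04 log units; within the scatter). Compound 4 `C[C@H](NC(=O)C(=O)Nc1ccc2c(c1)CCC2)C(=O)N[C@@H](CC(=O)O)C(=O)COc1c(F)c(F)cc(F)c1F` has not been measured; its change from compound 1 is 2,3-dihydro-1H-inden-5-yl in place of phenyl on an amide-type nitrogen. This also enlarges the ring on the amide-type nitrogen, but with one five-membered non-aromatic ring fused on rather than a single substituent, so the two large measured steps guide the direction more than the size. A lower number than for compound 1 is therefore expected, though a smaller gain than those two steps. Compound 4 is estimated at 200 nM, with a range from 70 nM to 600 nM. That estimate is expected to mean a 3.4-fold lower number from compound 1 to compound 4 (0.53 log units; beyond the scatter).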

Compound 4, half-maximal inhibitory concentration: 200 nM
Estimate against measurement, compound 4: no gap at the digits printed; the measured number falls inside the stated range.
By their numbers in this assay, from the lowest: compounds 3 and 2 (each within the scatter of the next); then compound 4; then compound 1.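

In this assay, fusing a five-membered non-aromatic ring onto the phenyl on the amide-type nitrogen also lowers the number (a 3.4-fold lower number from compound 1 to compound 4 (0.53 log units; beyond the scatter)), so the gain at this nitrogen is not confined to single substituents. The gain is smaller than with those single groups, as compound 4 sits above both of them (a 3.3-fold higher number from compound 2 to compound 4 (0.52 log units; beyond the scatter); a 3.6-fold higher number from compound 3 to compound 4 (0.55 log units; beyond the scatter)), which places it in a middle tier between compound 1 and the pair of compound 2 and compound 3. No measurement shown here explains this gap.

Still open, from the compounds shown here alone, is whether the fused ring must be all carbon or could carry an amine in its non-aromatic part. It is also unclear whether a carboxylic acid or a longer chain on the phenyl would keep, extend or lose the gain.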